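A change at the outer aryl group of a quinoline-free shared core

The source may hold more compounds than are shown below. What is called first, only, known or untested is meant among the compounds shown, and "the series" means these compounds.

Three compounds share one core and differ only in the group attached to it. Compound 1 `COc1ccc(Oc2ccc3c(NCCCNCc4cccc(OC)c4O)ccnc3c2)cc1` gives 9.28 in a physicochemical assay for acid dissociation. Compound 2 `COc1cccc(CNCCCNc2ccnc3cc(Oc4ccc(F)cc4)ccc23)c1O` gives 9.28 in this assay, and compound 3 `COc1cccc(CNCCCNc2ccnc3cc(-c4ccc(C(F)(F)F)cc4)ccc23)c1O` gives 9.47 in this assay. The steps of a number 0.19 log units higher from compound 1 to compound 3 (within the scatter) and a number 0.19 log units higher from compound 2 to compound 3 (within the scatter) show that compound 3 sits alongside the others, its number separated from theirs only by the usual scatter; the step of no change at the digits printed from compound 1 to compound 2 (within the scatter) tells the same of the first two.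

Compound 4 `COc1cccc(Oc2ccc3c(NCCCNCc4cccc(OC)c4O)ccnc3c2)c1` has not yet been measured. It differs from compound 3 as follows: 3-methoxyphenoxy in place of 4-(trifluoromethyl)phenyl on an aromatic carbon. Going by the values given here, the steps that bear on this are a number 0.19 log units higher from compound 1 to compound 3 (within the scatter) and a number 0.19 log units higher from compound 2 to compound 3 (within the scatter), each of them small, and going back from compound 3 towards a phenoxy group such as those in compounds 1 and 2 is therefore expected to move the number little, if at all. The expected step of a number 0.17 log units lower from compound 3 to compound 4 (within the scatter) lies within the scatter. Compound 4 is estimated at 9.3, with a range from 9 to 9.6.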

Compound 4, acid dissociation constant: 9.28
The estimate for compound 4 lay 0.02 log units above the measured number; low and high end bracket the measured number.
By their numbers in this assay, from the lowest: compounds 1, 2, 4 and 3 (each within the scatter of the next).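

In this assay, going by these compounds alone, moving the methoxy group around the outer ring, with 3-methoxyphenyl in place of 4-methoxyphenyl on the oxygen, gives no change at the digits printed from compound 1 to compound 4 (within the scatter) and is the first direct test of where that group sits. Replacing the fluoro-bearing outer ring with the same 3-methoxyphenyl gives no change at the digits printed from compound 2 to compound 4 (within the scatter), so all three phenoxy compounds, 1, 2 and 4, now share one printed number. Returning to a phenoxy group from the directly attached 4-(trifluoromethyl)phenyl gives a number 0.19 log units lower from compound 3 to compound 4 (within the scatter), which repeats at this place, with a third phenoxy group, the small size of the earlier steps.

As far as these compounds go, whether an amine or a carboxylic acid on the outer ring would leave this number just as steady remains open. No measurement is available to explain the steadiness seen so far.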